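The source may hold more compounds than are shown below. What is called first, only, known or untested is meant among the compounds shown, and "the series" means these compounds.

Compound 1 `CC(=O)c1cc(C(=O)N[C@H](C)Cn2ccc(-c3cc(F)c(C#N)c(Cl)c3)n2)n[nH]1`: "not determined" (no result reported)
Compound 2 `CC(O)c1ccc(C(=O)N[C@@H](C)Cn2ccc(-c3ccc(C#N)c(Cl)c3)n2)cc1`: > 30000 nM

Both compounds were taken into an ADME assay on PC-3 cells (Homo sapiens) for cytotoxicity, read by CCK-8 assay, with a stated time of 6 days (a higher number here means a weaker inhibitor, a lower number a stronger inhibitor), but only one of them gives any reading. Compound 1 has no reported result, so it offers no comparison. Compound 2 stands at > 30000 nM, and this is a limit of the assay, not a number.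

Compound 3 `COC(=O)/C=C/C(=O)N[C@@H](C)Cn1ccc(-c2ccc(C#N)c(Cl)c2)n1` keeps the shared core of compound 2 and changes the group on the carbonyl carbon: 2-(methoxycarbonyl)ethenyl in place of 4-(1-hydroxyethyl)phenyl on a carbonyl carbon. It carries 2-(methoxycarbonyl)ethenyl in place of 4-(1-hydroxyethyl)phenyl, and its ring-bearing group is therefore replaced by one with no ring.

For the measured compounds named here, no measured step bears on this change, and the only guide is compound 2, with the limit of > 30000 nM in this assay, at which 1 of the 2 values shown sits. In this assay the expected change is small, if any, and toward a stronger inhibitor: an at least 1.5-fold lower number from compound 2 to compound 3 (0.17 log units; that floor lies within the scatter). For compound 3 the estimated value is 20000 nM, with an expected range from 6000 nM to 30000 nM.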

Compound 3, half-maximal inhibitory concentration: > 30000 nM
Compound 3: no number, only a limit; the forecaster's own chance of this, stated with the estimate: 55%; middle value at least 1.5-fold (0.17 log units) away from the limit.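

Compound 2 and compound 3 both read as limits, not numbers, so no step between them can be read: the limit of > 30000 nM in this assay, at which 2 of the 3 values shown sit.

The compounds shown leave open whether 2-(methoxycarbonyl)ethenyl and 4-(1-hydroxyethyl)phenyl on the carbonyl carbon differ at all in this assay.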